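A few compounds are considered here, and "the series" means these few. Any claim that something is new, unique, unknown or untested is made for them only; others in the source may bear on it.

The series rests on one shared core, seen in compound 1 `C#CCSc1nc(Nc2ccc(Cl)cc2)c2ccncc2n1`, compound 2 `C#CCSc1nc(Nc2ccc(Br)cc2)c2ccncc2n1`, compound 3 `C#CCSc1nc(Nc2ccc([N+](=O)[O-])cc2)c2ccncc2n1` and the not yet measured compound 4 `C#CCSc1nc(Nc2ccc(OC)cc2)c2ccncc2n1`. In a functional assay on PC-3 cells (Homo sapiens) for inhibition, read by MTT assay, with a stated time of 72 h (a lower number here means a stronger inhibitor, a higher number a weaker inhibitor), compound 1 gives 19000 nM. In this assay compound 2 gives 26000 nM, which amounts to a 1.4-fold higher number from compound 1 to compound 2 (0.14 log units; within the scatter). For compound 3 this assay reports only a limit, > 80000 nM. That limit is the limit of > 80000 nM in this assay, at which 1 of the 3 values shown sits. Compound 3 thus stands as the weakest of the three measured, with an at least 4.2-fold higher number from compound 1 to compound 3 (0.62 log units; beyond the scatter) and an at least 3.0-fold higher number from compound 2 to compound 3 (0.48 log units; beyond the scatter).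

The change to compound 4 is methoxy in place of nitro on an aromatic carbon. Within the data shown here, no measured step goes from nitro to methoxy. The two steps that put nitro in place of chloro or bromo both weakened inhibition beyond the scatter, so taking the nitro away is expected to bring the number back toward the range of compounds 1 and 2 rather than to push it further up, though with wide uncertainty. Compound 4 is therefore expected to give 30000 nM, within 10000 nM to 90000 nM. That estimate means an expected step of an at least 2.6-fold lower number from compound 3 to compound 4 (0.42 log units; beyond the scatter).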

Compound 4, half-maximal inhibitory concentration: 15100 nM
Compound 4: the middle estimate sits 2.0-fold (0.30 log units) above what was measured; low and high end bracket the measured number.
By their numbers in this assay, from the lowest: compounds 4, 1 and 2 (each within the scatter of the next). At a limit, above all of these: compound 3.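

In this assay methoxy joins chloro and bromo at this position, with a 1.3-fold lower number from compound 1 to compound 4 (0.10 log units; within the scatter) and a 1.7-fold lower number from compound 2 to compound 4 (0.24 log units; within the scatter), so these three groups cannot be told apart here. Among the four groups, nitro alone stands apart, and putting methoxy in its place gives an at least 5.2-fold lower number from compound 3 to compound 4 (0.72 log units; beyond the scatter), which shows that the weak reading of compound 3 does not extend to every group that differs from the halogens. That step is a bound and not an exact size, because compound 3 stands at a limit: the limit of > 80000 nM in this assay, at which 1 of the 4 values shown sits.

As far as these compounds go, how an amine, a hydroxyl or a longer chain such as ethoxy would read at this position stays open. Also open, from the compounds shown here alone, is whether nitro would stand apart in the same way with another group elsewhere on the shared core.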